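Amine tail swap: bipiperidine to pyridylpiperazine

The source may report more compounds than this note shows. Statements on the series, on what has been measured and on what is new or still open speak of the compounds shown alone.

In a functional assay on MCF7 cells (Homo sapiens) for antiproliferative activity, read by MTT assay, with a stated time of 72 h (on this read-out lower numbers stand for stronger inhibition and higher numbers for weaker inhibition), compound 1 `CCN(CC)CCCOc1cc2ncnc(Nc3ccc(C#N)cc3)c2cc1OC` reaches only a limit of the assay, > 100000 nM. Compound 2 `COc1cc2c(Nc3ccc(C#N)cc3)ncnc2cc1OCCCN1CCC(C)CC1` gives 43100 nM, and compound 3 `COc1cc2c(Nc3ccc(C#N)cc3)ncnc2cc1OCCCN1CCC(N2CCCCC2)CC1` gives 19600 nM, the lowest of the two numbers shown. The steps of an at least 2.3-fold lower number from compound 1 to compound 2 (0.36 log units; beyond the scatter), an at least 5.1-fold lower number from compound 1 to compound 3 (0.70 log units; beyond the scatter) and a 2.2-fold lower number from compound 2 to compound 3 (0.34 log units; beyond the scatter) all lower the number, each at least modestly, and each changes only the amine tail. Compound 4 `COc1cc2c(Nc3ccc(C#N)cc3)ncnc2cc1OCCCN1CCN(c2ccncc2)CC1` carries 4-(pyridin-4-yl)piperazin-1-yl in place of 4-(piperidin-1-yl)piperidin-1-yl on a saturated chain carbon, three bonds along the chain from an oxygen on an aromatic ring. Since every measured tail change lowered the number only modestly, a further tail change is expected to move the number little, within the scatter or slightly lower. Compound 4 is therefore expected to give 15000 nM, between 5000 nM and 45000 nM. The expected step is a 1.3-fold lower number from compound 3 to compound 4 (0.12 log units; within the scatter).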

Compound 4, half-maximal inhibitory concentration: 22900 nM
Estimate against measurement, compound 4: 1.5-fold (0.18 log units) below, and the stated range covers the measured number.
By their numbers in this assay, from the lowest: compounds 3, 4 and 2 (each within the scatter of the next, the first and the last beyond it). At a limit, above all of these: compound 1.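

At this place on the chain, in this assay, a tail with an aromatic ring and a piperazine serves as well as the saturated tails: a 1.2-fold higher number from compound 3 to compound 4 (0.07 log units; within the scatter), and a 1.9-fold lower number from compound 2 to compound 4 (0.27 log units; within the scatter). The tails of compound 2, compound 3 and compound 4 thus differ from the diethylamino tail more than they differ in sequence from one another, though an at least 4.3-fold lower number from compound 1 to compound 4 (0.64 log units; beyond the scatter) remains only a bound: the limit of > 100000 nM in this assay, at which 1 of the 4 values shown sits.

Going by these compounds, it remains open whether a phenyl group in place of pyridin-4-yl on the piperazine, or a morpholin-4-yl tail, would give a different number. On these data alone, a shorter chain carrying the same 4-(pyridin-4-yl)piperazin-1-yl group is equally open.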